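Trimming the benzyl halogens on a diaminoquinoxaline growth inhibitor

The compounds below may be only part of what the source reports. "The series", "measured", "known", "first", "only" and "open" are said of these compounds alone.

Three compounds share a core and were measured in a functional assay on SK-MEL-28 cells (Homo sapiens) for inhibition, read by sulforhodamine B assay, with a stated time of 48 h; on this read-out lower numbers stand for stronger inhibition of growth and higher numbers for weaker inhibition of growth. Compound 1 `Nc1cc(N)c2nc(-c3ccccc3)c(NCc3ccc(Cl)c(Cl)c3)nc2c1` carries a 3,4-dichlorobenzyl group on an amine attached to the core and gives 18600 nM. Compound 2 `CCOC(=O)[C@H](CCC(=O)O)NC(=O)c1ccc(Sc2nc3cc(N)cc(N)c3nc2-c2ccccc2)cc1`, which instead bears a sulfur-linked aryl amide of a glutamate ester, gives 6760 nM, while its oxygen-linked counterpart, compound 3 `CCOC(=O)[C@H](CCC(=O)O)NC(=O)c1ccc(Oc2nc3cc(N)cc(N)c3nc2-c2ccccc2)cc1`, gives 14500 nM. Among these three numbers compound 1 sits highest; its gap to compound 3 lies within the scatter of the method, so the two cannot be ordered, whereas the gap to compound 2 lies beyond it.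

The next compound, compound 4 `Nc1cc(N)c2nc(-c3ccccc3)c(NCc3ccc(F)cc3)nc2c1`, changes only the benzyl group of compound 1: 4-fluorophenyl in place of 3,4-dichlorophenyl on a saturated chain carbon bound to a nitrogen on an aromatic ring. For the measured compounds named here, no pair of measured compounds shows this kind of change, so its effect has to be guessed. Removing one halogen and moving the remaining one seems more likely to loosen than to tighten growth inhibition, and a modest step is expected. The estimated step of a 1.4-fold higher number from compound 1 to compound 4 (0.15 log units; within the scatter) is toward a higher number. Compound 4 is therefore expected to give about 26000 nM, with a plausible range from 9000 nM to 75000 nM.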

Compound 4, concentration for 50% growth inhibition: 1910 nM
Compound 4: middle estimate off by 14-fold (1.13 log units), on the high side; the whole stated range lies above it.
By their numbers in this assay, from the lowest: compound 4; then compound 2; then compounds 3 and 1 (each within the scatter of the next).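

In this assay, the benzyl group on the amine proves to be a sensitive place on the shared core: 4-fluorophenyl in place of 3,4-dichlorophenyl gives a 9.7-fold lower number from compound 1 to compound 4 (0.99 log units; beyond the scatter), a step toward stronger inhibition of growth and beyond the scatter. For the compounds shown here, the earlier compounds offered no pair differing in one place, so this is the first direct sign that a change on a saturated chain carbon bound to a nitrogen on an aromatic ring can shift this read-out, here with the aromatic ring kept and only its halogens altered. Nothing measured here accounts for the size of the step or says why it points this way.

Going by these compounds alone, the single step combines the loss of both chlorine atoms with the arrival of a fluorine, so it cannot show which of these matters, and an unsubstituted benzyl group or one chlorine in place of the fluorine would separate the two. Going by these compounds, whether a longer chain between the amine and the aromatic ring would keep this level of growth inhibition also remains open.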